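Anilino-substituent changes on the shared core

The source may report more compounds than this note shows. Statements on the series, on what has been measured and on what is new or still open speak of the compounds shown alone.

compound 1: `C=CC(=O)Nc1cccc(NC(=O)CSc2nc(Nc3ccccc3)c3ccccc3n2)c1` — 8740 nM
compound 2: `C=CC(=O)Nc1cccc(NC(=O)CSc2nc(Nc3cc(OC)c(OC)c(OC)c3)c3ccccc3n2)c1` — > 50000 nM

In a functional assay on PC-3 cells (Homo sapiens) for inhibition, read by MTT assay, with a stated time of 72 h (a lower number here means a stronger inhibitor, a higher number a weaker inhibitor), compound 1 gives 8740 nM. For compound 2 only a limit is reported, > 50000 nM, sitting at the limit of > 50000 nM in this assay, at which 1 of the 2 values shown sits. Compound 2 thus stands at the edge of this assay, and the step of an at least 5.7-fold higher number from compound 1 to compound 2 (0.75 log units; beyond the scatter) is known only as a bound. Compound 3 `C=CC(=O)Nc1cccc(NC(=O)CSc2nc(Nc3ccc(Cl)cc3Cl)c3ccccc3n2)c1` differs from compound 2 by 2,4-dichlorophenyl in place of 3,4,5-trimethoxyphenyl on a nitrogen on an aromatic ring. Going by the values given here, no measured step involves a dichlorophenyl; the only step bearing on this position, an at least 5.7-fold higher number from compound 1 to compound 2 (0.75 log units; beyond the scatter), shows that trimethoxyphenyl weakened inhibition beyond the scatter. With that group gone, a return toward the level of compound 1 is expected, with wide uncertainty. Compound 3 is expected to give 12000 nM (3500 nM to 50000 nM) in this assay. This estimate means an expected step of an at least 4.1-fold lower number from compound 2 to compound 3 (0.61 log units; beyond the scatter), downward from the limit.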

Compound 3, half-maximal inhibitory concentration: 25700 nM
Compound 3: middle estimate off by 2.1-fold (0.33 log units), on the low side; low and high end bracket the measured number.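

Substitution on this phenyl ring now has a measured cost: 2,4-dichlorophenyl in place of phenyl gives a 2.9-fold higher number from compound 1 to compound 3 (0.47 log units; beyond the scatter) in this assay, so both substituted rings shown read weaker than the phenyl of compound 1. Against the trimethoxyphenyl, the change reads only as an at least 1.9-fold lower number from compound 2 to compound 3 (0.28 log units; that floor lies within the scatter). No order between these two substituted rings can therefore be drawn.

From the compounds shown here alone, whether a single chlorine or a single methoxy group would stay near compound 1 remains open. So does whether any group at this position could give a lower number than compound 1.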